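Notes on Compound 3: 3-(tert-butyl)phenyl Analogue of Compound 1

The source may report more compounds than this note shows. Statements on the series, on what has been measured and on what is new or still open speak of the compounds shown alone.

Compound 1 `COc1cc(NC(=O)Nc2cc(Nc3ccc(OC)c(C)c3)ncn2)cc(OC)c1` gives 19.7% in a functional assay on NCI-H1581 cells (Homo sapiens) for inhibition, read by MTT assay, with a stated time of 48 h, tested at 10 uM (on this read-out higher numbers stand for more inhibition at the one concentration tested (going by the name of the read-out) and lower numbers for less inhibition), the lower of the two numbers recorded so far. Compound 2 `COc1cc(Nc2cc(NC(=O)Nc3c(Cl)cccc3Cl)ncn2)cc(OC)c1` shares the core but differs from compound 1 in several places. In this assay compound 2 gives 68%, and this value stands above that of compound 1 by a gap beyond the usual scatter. Since these two compounds are not a single-change pair, their values show only that the series spans a wide range.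

Compound 3 `COc1cc(NC(=O)Nc2cc(Nc3cccc(C(C)(C)C)c3)ncn2)cc(OC)c1` is the next candidate. Relative to compound 1 the change is 3-(tert-butyl)phenyl in place of 4-methoxy-3-methylphenyl on a nitrogen on an aromatic ring. Going by the values given here, no measured step of this kind exists to set its size, so the expected change is a number 8.3 percentage points higher from compound 1 to compound 3 (within the scatter), of modest size, possibly none beyond the scatter, with an upward direction judged somewhat more likely than a downward one. Compound 3 is therefore estimated at 28%, within a range of 5% to 55%.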

Compound 3, a percentage reported as inhibition, at one concentration (the size of the read-out at that concentration, not a potency): 35.1%
For compound 3 the middle estimate is 7.1 percentage points below the measured one; the measured number falls inside the stated range.
By their numbers in this assay, from the lowest: compound 1; then compound 3; then compound 2.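

At this place, on a nitrogen on an aromatic ring, the series now has its first single-change step: in this assay, 3-(tert-butyl)phenyl in place of 4-methoxy-3-methylphenyl gives a number 15.4 percentage points higher from compound 1 to compound 3 (beyond the scatter), a modest step. The read-out therefore responds to the aryl group at this place, and it does not fall when the entering group carries no hydrogen-bond acceptor while the leaving group carries one. No independent measurement bears on the origin of this step.

The exchange removes the methoxy and methyl groups and adds the tert-butyl group in one move, so the share of each remains unresolved. Also open, going by these compounds, is how the read-out would respond to a phenyl ring at this place bearing an amine or a carboxylic acid.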